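Diacylhydrazine series: swapping the aryl acyl group for hexyl

This account rests on a few compounds, and the source may have more. Where it says the series, first, only, none or still open, it means among the compounds named here.

Measured so far:
- compound 1, `CC(C)(C)N(NC(=O)c1ccc(F)cc1)C(=O)c1ccccc1Cl` — 389 nM
- compound 2, `CC(C)c1ccc(C(=O)NN(C(=O)c2ccccc2Cl)C(C)(C)C)cc1` — 24.6 nM

In an assay on cells for agonist activity at ecdysone receptor (Bombyx mori), read by a luciferase reporter, with a stated time of 24 h (a lower number here means that less compound is needed, a higher number that more compound is needed for the effect), compound 1 gives 389 nM, the highest of the two numbers recorded; its nearest neighbour is compound 2, reached by a 16-fold lower number from compound 1 to compound 2 (1.20 log units; beyond the scatter), with isopropyl in place of fluoro on an aromatic carbon.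

Compound 3, `CCCCCCC(=O)NN(C(=O)c1ccccc1Cl)C(C)(C)C`, differs from compound 1 as follows: hexyl in place of 4-fluorophenyl on a carbonyl carbon. Among the measured compounds shown here, no measured step touches this change; the one step recorded, from compound 1 to compound 2, alters only a substituent on the ring that is now removed altogether, so it offers no direct guidance on losing the ring. The expectation for compound 3 is therefore wide and leans toward a larger number than compound 1, as a 3.9-fold higher number from compound 1 to compound 3 (0.59 log units; beyond the scatter), with compound 3 estimated at 1500 nM in this assay, within a range of 200 nM to 10000 nM.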

Compound 3, half-maximal effective concentration: 741 nM
The estimate for compound 3 lay 2.0-fold (0.31 log units) above the measured number, and the stated range covers the measured number.
By their numbers in this assay, from the lowest: compound 2; then compounds 1 and 3 (each within the scatter of the next).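

Hexyl in place of 4-fluorophenyl on a carbonyl carbon gives a 1.9-fold higher number from compound 1 to compound 3 (0.28 log units; within the scatter) in this assay, so an aromatic ring at this place is not required to reach a number of this size. The earlier step changed only a substituent on that ring, whereas this one removes the ring altogether and the result still stays within the scatter of compound 1. Nothing on hand gives a reason for this outcome.

Going by these compounds, whether the length of the chain matters remains open, and a butyl or an octyl chain on this carbonyl carbon would address it. Also open, on these data alone, is whether a cyclohexyl group behaves as hexyl does here, and how a chain ending in an amine or a carboxylic acid reads in the same assay.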